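A few compounds are considered here, and "the series" means these few. Any claim that something is new, unique, unknown or untested is made for them only; others in the source may bear on it.

Measured compounds:

Compound 1 `CCOC(=O)c1sc(NC(=O)Cn2cc(-c3cccs3)nn2)nc1C` – in a functional assay on BMDM cells (Mus musculus, strain C57BL/6) for inhibition, with a stated time of 2 days (a lower number here means a stronger inhibitor, a higher number a weaker inhibitor), compound 1 gives 20 nM
Compound 2 `Cc1csc(NC(=O)Cn2cc(-c3ccccc3Cl)nn2)n1` – in this assay compound 2 gives 1240 nM
Compound 3 `Cc1csc(NC(=O)Cn2cc(-c3cccc(N)c3)nn2)n1` – in this assay compound 3 gives 250 nM

Among these three numbers compound 3 stands second highest: compound 2 is nearest to it, and compound 1 is furthest, with the lower number. For the measured compounds named here, the one step measured in one place, a 5.0-fold lower number from compound 2 to compound 3 (0.70 log units; beyond the scatter), shows that swapping the aromatic group on the shared core can move the number clearly beyond the scatter.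

Compound 4 `Cc1csc(NC(=O)Cn2cc(-c3cccs3)nn2)n1` is not yet measured. It differs from compound 3 in one place, (thiophen-2-yl in place of 3-aminophenyl on an aromatic carbon). Going by the values given here, no measured step tells directly how thiophen-2-yl compares with 3-aminophenyl on this core. Compound 1 also carries thiophen-2-yl and shows the lowest number of the three, but it differs from compound 3 in two places, so only part of that gap can be credited to the aromatic group. The expectation is therefore a modest lowering, a 2.5-fold lower number from compound 3 to compound 4 (0.40 log units; beyond the scatter), with wide uncertainty. The estimate for compound 4 is 100 nM, expected to fall between 25 nM and 400 nM.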

Compound 4, half-maximal inhibitory concentration: 40 nM
Estimate against measurement, compound 4: 2.5-fold (0.40 log units) above; measured number inside the range.
By their numbers in this assay, from the lowest: compounds 1 and 4 (each within the scatter of the next); then compound 3; then compound 2.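

With only the aromatic group changing, thiophen-2-yl gives a 6.3-fold lower number from compound 3 to compound 4 (0.80 log units; beyond the scatter) and a 31-fold lower number from compound 2 to compound 4 (1.49 log units; beyond the scatter), so it has the lowest number of the three groups compared at this aromatic carbon of the shared core. The second comparison concerns a different position, with a 2.0-fold higher number from compound 1 to compound 4 (0.30 log units; within the scatter), so hydrogen and ethoxycarbonyl cannot be told apart in this assay and the low number of compound 1 does not depend on the ethoxycarbonyl group. Nothing shown here explains why thiophen-2-yl stands out at this position.

From the compounds shown here alone, whether a furan-2-yl group or an unsubstituted phenyl group would match thiophen-2-yl remains open. Going by these compounds, it is also open whether a carboxylic acid or a primary amide in place of the ethoxycarbonyl group would move the number on this thiophen-2-yl compound.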